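Swapping One Group on a Carbonyl Carbon

The compounds below may be only part of what the source reports. "The series", "measured", "known", "first", "only" and "open" are said of these compounds alone.

Measured so far in a functional assay on SNB-19 cells (Homo sapiens) for inhibition, read by sulforhodamine B assay, with a stated time of 48 h; on this read-out lower numbers stand for stronger inhibition of growth and higher numbers for weaker inhibition of growth:
- Compound 1 `O=C(Nc1cccc(-n2cc(-c3ccncc3)c(-c3ccc(Cl)c(O)c3)n2)c1)Nc1cccc(C(F)(F)F)c1` gives > 32500 nM
- Compound 2 `COc1cc(-c2nn(-c3cccc(NC(=O)c4cccc(C(F)(F)F)c4)c3)cc2-c2ccncc2)ccc1Cl` gives > 50000 nM

Neither entry is an exact number. Compound 2 has only a limit in this assay, > 50000 nM, and this is all that is known of where it stands. Among the measured compounds shown here, compound 1 also has only a limit, > 32500 nM, so the two compounds cannot be ranked against each other, and no measured step is available to show how large a single change might be.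

Compound 3 `COc1cc(-c2nn(-c3cccc(NC(=O)Nc4cccc(C(F)(F)F)c4)c3)cc2-c2ccncc2)ccc1Cl` keeps the core of compound 2 and alters one group: (3-(trifluoromethyl)phenyl)amino in place of 3-(trifluoromethyl)phenyl on a carbonyl carbon. In words, (3-(trifluoromethyl)phenyl)amino stands in place of 3-(trifluoromethyl)phenyl on a carbonyl carbon. Compound 1 also carries the entering group on a carbonyl carbon, and its limit of > 32500 nM gives no sign of strong growth inhibition. The expected step, an at least 1.1-fold lower number from compound 2 to compound 3 (0.04 log units; that floor lies within the scatter), is therefore none beyond the usual scatter. Compound 3 is estimated at 45000 nM, within an expected range from 15000 nM to 100000 nM, and it may also be reported only as a limit.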

Compound 3, concentration for total growth inhibition: 4000 nM
The estimate for compound 3 lay 11-fold (1.05 log units) above the measured number, outside the stated range (below it).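

In this assay, the exchange of one group on a carbonyl carbon gives an at least 12-fold lower number from compound 2 to compound 3 (1.09 log units; beyond the scatter), the first sign that this place in the molecule can change growth inhibition; the entering group carries a hydrogen-bond donor that the leaving group lacks, although these data do not show that the donor is responsible. The entering group is not enough on its own, since the change of methyl in place of hydrogen on an oxygen on an aromatic ring, with that group present on both sides, gives an at least 8.1-fold lower number from compound 1 to compound 3 (0.90 log units; beyond the scatter). The first step is a lower bound rather than an exact size because compound 2 is reported only as a limit: the limit of > 50000 nM in this assay, at which 1 of the 3 values shown sits.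

The compounds shown do not reveal whether the hydrogen on the new nitrogen matters, which a methyl group on that nitrogen could test, or whether a longer chain such as ethyl on the oxygen would keep the effect. They also leave open how the result would change if a chlorine or a nitrile took the place of the trifluoromethyl group.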